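The compounds below may be only part of what the source reports. "The series", "measured", "known", "first", "only" and "open" are said of these compounds alone.

Of the compounds shown here, three with a shared core have been measured in an assay on isolated protein for inhibition of retinal dehydrogenase 2 (Homo sapiens); on this read-out lower numbers stand for stronger inhibition and higher numbers for weaker inhibition. Compound 1 `CC(Sc1nc2nn(CC3COC3)cc2c(=O)n1-c1ccccc1)c1ccccc1` gives 80 nM in this assay. Compound 2 `Cn1ccc2c(=O)n(-c3ccccc3)c(SCc3cccc(F)c3)nc21` gives 810 nM in this assay. Compound 3 `COc1cccc(C(C)Sc2nc3c(cnn3C)c(=O)n2-c2ccccc2)c1` gives 108 nM in this assay, which places it second highest of the three numbers: its nearest neighbour is compound 1, whose number lies within the scatter of its own, while compound 2 stands beyond the scatter with the higher number.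

The step under consideration leads from compound 3 to compound 4 `CC(Sc1nc2c(cnn2C)c(=O)n1-c1ccccc1)c1ccccc1`, which has not yet been measured in this assay. The change is hydrogen in place of methoxy on an aromatic carbon, sitting meta to a large group; cut one bond further out it reads as 3-methoxyphenyl to phenyl.

Among the measured compounds shown here, no pair of measured compounds that differ only in this place is available, so the size of the step is an expectation rather than a measured fact. Compound 1 also carries a plain phenyl at this position and gives 80 nM, a number within the scatter of compound 3, so the step is expected to stay within the scatter, in either direction. Compound 4 is accordingly estimated at 110 nM in this assay, with a range from 40 nM to 300 nM, meaning an expected step of a 1.0-fold higher number from compound 3 to compound 4 (0.01 log units; within the scatter).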

Compound 4, half-maximal inhibitory concentration: 110 nM
For compound 4 middle estimate and measured number coincide at the digits printed; the measured number falls inside the stated range.
By their numbers in this assay, from the lowest: compounds 1, 3 and 4 (each within the scatter of the next); then compound 2.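

In this assay, the exchange of methoxy for hydrogen on an aromatic carbon, which turns 3-methoxyphenyl into phenyl, comes out as a 1.0-fold higher number from compound 3 to compound 4 (0.01 log units; within the scatter) and so lies within the scatter. Among the compounds shown here, this is the first pair of compounds that differ only at this place, and it shows that on this core compound 3 and compound 4 cannot be told apart, whether the methoxy group is present or absent. In this pair, then, neither the two heavy atoms nor the hydrogen-bond acceptor counted for methoxy leaves a mark on the number that can be read beyond the scatter, although the data offer nothing that would explain this result.

What the compounds shown leave open is how far this tolerance extends, since a single exchange says nothing about an amine, a carboxylic acid or a longer chain such as butoxy at the same place. Going by these compounds, it also remains open whether the same exchange would read the same way on a compound with a different group elsewhere in the molecule, such as the core of compound 1.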